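From 3-fluorophenyl to 4-chlorophenyl at the assay limit

The source may hold more compounds than are shown below. What is called first, only, known or untested is meant among the compounds shown, and "the series" means these compounds.

In a functional assay on OVCAR-3 cells (Homo sapiens) for antiproliferative activity, read by MTT assay, with a stated time of 24 h (a higher number here means a weaker inhibitor, a lower number a stronger inhibitor), compound 1 (`Cc1cccc(-n2cc(-c3cccc(NS(=O)(=O)c4c[nH]c(=O)[nH]c4=O)c3)nn2)c1`) gives 4080 nM. Compound 2 (`O=c1[nH]cc(S(=O)(=O)Nc2cccc(-c3cn(-c4cccc(F)c4)nn3)c2)c(=O)[nH]1`) gives > 20000 nM, which is a limit of the assay and not a number; this is the limit of > 20000 nM in this assay, at which 1 of the 2 values shown sits. Compound 3 (`O=c1[nH]cc(S(=O)(=O)Nc2cccc(-c3cn(-c4ccc(Cl)cc4)nn3)c2)c(=O)[nH]1`) has 4-chlorophenyl in place of 3-fluorophenyl on an aromatic nitrogen of the five-membered ring (4-chlorophenyl in place of 3-fluorophenyl on an aromatic nitrogen). Within the data shown here, only one measured step bears on this change: an at least 4.9-fold higher number from compound 1 to compound 2 (0.69 log units; beyond the scatter), where fluoro replaces methyl on an aromatic carbon. That step lies beyond the scatter, so small changes on this outer ring can matter in this assay. Its size is only a bound, however, and chloro has not been measured here. A modest move towards a lower number is expected, and a result at the limit remains possible. The estimated step runs an at least 2.0-fold lower number from compound 2 to compound 3 (0.30 log units; that floor lies within the scatter). For compound 3 the estimate is 10000 nM, with an expected range of 2500 nM to 30000 nM.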

Compound 3, half-maximal inhibitory concentration: 2040 nM
Compound 3: the middle estimate sits 4.9-fold (0.69 log units) above what was measured, outside the stated range (below it).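

In this assay, the ring on the aromatic nitrogen can carry a halogen and still give a measurable value, since 4-chlorophenyl in place of 3-fluorophenyl gives an at least 9.8-fold lower number from compound 2 to compound 3 (0.99 log units; beyond the scatter). Fluoro on this ring therefore does not speak for every halogen here, and against the methyl-bearing ring the chloro-bearing one shows a 2.0-fold lower number from compound 1 to compound 3 (0.30 log units; within the scatter), so these two compounds cannot be told apart. Compound 2 stands at > 20000 nM, which is a limit of the assay and not a number: the limit of > 20000 nM in this assay, at which 1 of the 3 values shown sits.

This change swaps the halogen and moves it on the ring at once, so the compounds shown cannot say which of the two matters; 3-chlorophenyl or 4-fluorophenyl would separate them. As far as these compounds go, how an amine or a carboxylic acid on this ring would read also stays open.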